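The source may report more compounds than this note shows. Statements on the series, on what has been measured and on what is new or still open speak of the compounds shown alone.

The compounds share a single core. In a functional assay on SNB-75 cells (Homo sapiens) for inhibition, read by sulforhodamine B assay, with a stated time of 48 h (on this read-out higher numbers stand for weaker inhibition of growth and lower numbers for stronger inhibition of growth), compound 2 `Nc1cc(N)c2nc(-c3ccccc3)c(Oc3ccc(F)cc3)nc2c1` gives 23400 nM. Compound 1 `CCOC(=O)[C@H](CCC(=O)O)NC(=O)c1ccc(Sc2nc3cc(N)cc(N)c3nc2-c2ccccc2)cc1` gives 32400 nM in this assay, a number within the scatter of that of compound 2, so the two cannot be ranked. For compound 3 `CCOC(=O)[C@H](CCC(=O)O)NC(=O)c1ccc(CNc2nc3cc(N)cc(N)c3nc2-c2ccccc2)cc1` the this assay reports only a limit, < 100000 nM, and no number. Compound 4 `Nc1cc(N)c2nc(-c3ccccc3)c(NCc3ccc(F)cc3)nc2c1` has not yet been measured; it carries (4-fluorobenzyl)amino in place of 4-fluorophenoxy on an aromatic carbon. For the measured compounds named here, no measured pair matches this change. The step expected from compound 2 to compound 4 in this assay is a modest weakening, a 2.1-fold higher number from compound 2 to compound 4 (0.33 log units; beyond the scatter), with the limit of < 100000 nM in this assay, at which 1 of the 3 values shown sits, as the only hint. Compound 4 is thus estimated at 50000 nM, with a likely range from 15000 nM to 150000 nM.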

Compound 4, concentration for 50% growth inhibition: 2140 nM
Compound 4: middle estimate off by 23-fold (1.37 log units), on the high side; the measured number lies below the stated range.
By their numbers in this assay, from the lowest: compound 4; then compounds 2 and 1 (each within the scatter of the next).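

In this assay the place on the aromatic carbon next to the ring nitrogen proves sensitive to its substituent: (4-fluorobenzyl)amino in place of 4-fluorophenoxy gives an 11-fold lower number from compound 2 to compound 4 (1.04 log units; beyond the scatter) and a large step. The earlier compounds shown here offered no measured step at this position. The entering group brings a hydrogen-bond donor and one more heavy atom, but nothing measured here bears on the cause of the step.

Open, going by these compounds, is whether the linking nitrogen or the added carbon carries the step. A 4-fluoroanilino or a 4-fluorobenzyloxy group at this position would separate the two.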